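The source may report more compounds than this note shows. Statements on the series, on what has been measured and on what is new or still open speak of the compounds shown alone.

Of the compounds shown here, two have so far been measured in an assay on NK92 cells for inhibition of interleukin-15 (Homo sapiens), read by AlphaScreen, with stated times of 30 min and 1 h; a lower number here means a stronger inhibitor, a higher number a weaker inhibitor. Compound 1 `Cn1c(Cc2nn(C)c(=O)c3ccccc23)nnc1SCC(=O)Nc1ccc(Cl)cc1Cl` gives 4500 nM in this assay. Compound 2 `CCOC(CCn1c(Cc2nn(C)c(=O)c3ccccc23)nnc1SCCCCCCCC(=O)Nc1ccc(Cl)cc1Cl)OCC` gives 30000 nM in this assay, the higher of the two numbers, so compound 2 is the weaker inhibitor of the pair, and the gap to compound 1 lies beyond the usual scatter. Going by the values given here, the two structures differ in several places at once, so these numbers show only that compound 2 is weaker, not what any single change would do on its own.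

Compound 3 `Cn1nc(Cc2nnc(SCCCCCCCC(=O)Nc3ccc(Cl)cc3Cl)[nH]2)c2ccccc2c1=O` has not yet been measured in this assay. It differs from compound 2 in one place: hydrogen in place of 3,3-diethoxypropyl on an aromatic nitrogen. Among the compounds with values here, no measured pair shows this exact change, so there is no direct guide to its size. Since compound 2 already stands at the weak end with 30000 nM, a step downward in number toward a stronger inhibitor seems somewhat more likely than a further step up, though a change within the scatter is also possible. The expected step is a 2.0-fold lower number from compound 2 to compound 3 (0.30 log units; within the scatter). For compound 3 the estimated value is 15000 nM, with a range from 4000 nM to 50000 nM.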

Compound 3, half-maximal inhibitory concentration: 280 nM
Beside the measured number, compound 3's estimate is 54-fold (1.73 log units) above it; measured number outside the range, below it.
By their numbers in this assay, from the lowest: compound 3; then compound 1; then compound 2.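

In this assay, replacing the 3,3-diethoxypropyl group on the aromatic nitrogen with hydrogen gives a 110-fold lower number from compound 2 to compound 3 (2.03 log units; beyond the scatter) in a single change, a large step well beyond the scatter. The earlier pair differed in several places at once and could not tie any difference to one site, whereas this pair shows that the group on this ring nitrogen alone can shift the number greatly, with hydrogen there giving the far stronger inhibitor of the two. No measurement is available that accounts for the size of this step.

The compounds shown leave open how the number responds to anything between these two extremes on this nitrogen, such as an ethyl group or a plain propyl chain without the two ethoxy groups, which would help separate the effect of the chain from that of its acetal end. Going by these compounds, it also remains open whether a propyl chain ending in an amine or a carboxylic acid would be tolerated at this position, or whether only hydrogen keeps the stronger inhibition seen for compound 3.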